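The source may report more compounds than this note shows. Statements on the series, on what has been measured and on what is new or still open speak of the compounds shown alone.

Values in a functional assay on MGC-803 cells (Homo sapiens) for inhibition, read by MTT assay, with a stated time of 48 h; a higher number here means a weaker inhibitor, a lower number a stronger inhibitor:
compound 1 `CCCCC(=O)N(Cc1ccc(OC)c(O)c1)c1cc(OC)c(OC)c(OC)c1`: 66 nM
compound 2 `COc1ccc(CN(C(=O)CO)c2cc(OC)c(OC)c(OC)c2)cc1O`: 160 nM
compound 3 `COc1ccc(N(Cc2cc(OC)c(OC)c(OC)c2)C(=O)CCl)cc1O`: 24500 nM

Compound 2 holds the middle place among these three numbers, with compound 1 lower and compound 3 far higher. Compound 4 `COc1ccc(CN(C(=O)C2CC2)c2cc(OC)c(OC)c(OC)c2)cc1O` alters one group of compound 2: cyclopropyl in place of hydroxymethyl on a carbonyl carbon. In words, this is cyclopropyl in place of hydroxymethyl on a carbonyl carbon.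

Among the measured compounds shown here, one measured step bears on this change: a 2.4-fold higher number from compound 1 to compound 2 (0.38 log units; beyond the scatter), where hydroxy takes the place of propyl on a saturated chain carbon bound to a carbonyl carbon. That step is modest but beyond the scatter. Compound 4 also has no hydroxy in this part of the molecule, so it is closer to compound 1 here. For the measured compounds named here, compound 3 has no single-place step to the others and adds nothing. Going by the values given here, a modest move to a lower number is therefore expected, though one step is thin evidence and no measured compound carries cyclopropyl. The expected change is a 1.8-fold lower number from compound 2 to compound 4 (0.25 log units; within the scatter). For compound 4 the estimated value is 90 nM, with an expected range of 30 nM to 280 nM.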

Compound 4, half-maximal inhibitory concentration: 59 nM
Compound 4: the middle estimate sits 1.5-fold (0.18 log units) above what was measured; the range from low to high includes it.
By their numbers in this assay, from the lowest: compounds 4 and 1 (each within the scatter of the next); then compound 2; then compound 3.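

Replacing hydroxymethyl with cyclopropyl on this carbonyl carbon in this assay gives a 2.7-fold lower number from compound 2 to compound 4 (0.43 log units; beyond the scatter) and shows that a small ring can sit at this position without loss of inhibition. Changing butyl to cyclopropyl gives a 1.1-fold lower number from compound 1 to compound 4 (0.05 log units; within the scatter) so this open chain and this ring cannot be told apart here, and the two compounds without the hydroxy of compound 2 now agree. No measurement shown explains why the numbers fall this way.

From the compounds shown here alone, it remains open whether a larger ring such as cyclohexyl, or an aminomethyl group, on this carbonyl carbon would keep the number this low. A methoxymethyl group would test whether the free hydroxy of compound 2 is what matters, and that question also stays unanswered.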